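Compound 3 to compound 4 at the assay limit

This account rests on a few compounds, and the source may have more. Where it says the series, first, only, none or still open, it means among the compounds named here.

In a functional assay on HepG2 cells (Homo sapiens) for antiproliferative activity, read by MTT assay, with a stated time of 48 h (a lower number here means a stronger inhibitor, a higher number a weaker inhibitor), compound 1 `C#CC(C)OC(=O)c1ccc(C(CC)(CC)c2ccc(OCCC(O)(CC)CC)c(C)c2)n1CC` gives > 50000 nM as a limit of the assay and not a number. Compound 2 `C#CCCOC(=O)c1ccc(C(CC)(CC)c2ccc(OCCC(O)(CC)CC)c(C)c2)n1CC` gives > 50000 nM as a limit as well. Compound 3 `CCn1c(C(=O)Nc2cccc(C(F)(F)F)c2)ccc1C(CC)(CC)c1ccc(OCCC(O)(CC)CC)c(C)c1` gives > 50000 nM as a limit too. The series therefore stands at the limit of > 50000 nM in this assay, at which 3 of the 3 values shown sit, and compound 3 has no rank within it.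

Compound 4 `CCOC(=O)CN(C)C(=O)c1ccc(C(CC)(CC)c2ccc(OCCC(O)(CC)CC)c(C)c2)n1CC` carries the change ((ethoxycarbonyl)methyl)(methyl)amino in place of (3-(trifluoromethyl)phenyl)amino on a carbonyl carbon in which ((ethoxycarbonyl)methyl)(methyl)amino takes the place of (3-(trifluoromethyl)phenyl)amino on a carbonyl carbon.

The measured exchanges on a carbonyl carbon are a step that the two limits leave unreadable from compound 1 to compound 3 and a step that the two limits leave unreadable from compound 2 to compound 3 while a step that the two limits leave unreadable from compound 1 to compound 2 concerns only the group on the oxygen. With no size to carry over from a step that the two limits leave unreadable from compound 2 to compound 3 no step beyond the scatter is expected in this assay in either direction. The estimated step is a number no higher from compound 3 to compound 4 (the limit leaves the size open) and a reading at the limit is the likeliest outcome. For compound 4 the estimate is 50000 nM with an expected range from 20000 nM to 100000 nM in this assay.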

Compound 4, half-maximal inhibitory concentration: 25300 nM
For compound 4 the middle estimate is 2.0-fold (0.30 log units) above the measured one; the measured number falls inside the stated range.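

In this assay, compound 4 is the only compound shown that reads as a number and not as a limit, so the group on this carbonyl carbon is not tied to the ceiling of the series: the limit of > 50000 nM in this assay, at which 3 of the 4 values shown sit. Placing ((ethoxycarbonyl)methyl)(methyl)amino on the carbonyl carbon gives an at least 1.9-fold lower number from compound 3 to compound 4 (0.29 log units; that floor lies within the scatter), an at least 1.9-fold lower number from compound 2 to compound 4 (0.29 log units; that floor lies within the scatter) and an at least 1.9-fold lower number from compound 1 to compound 4 (0.29 log units; that floor lies within the scatter), so a gain beyond the scatter is not established, though each figure is only a floor. The steps among compounds 1, 2 and 3 cannot be read.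

As far as these compounds go, the true size of these steps remains open, as does which part of the entering group matters. A carboxylic acid in place of the ethoxycarbonyl, or a plain dimethylamino group on the carbonyl carbon, would help separate these parts in this assay.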